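Side-chain changes on a flat growth-inhibition read-out

The compounds below may be only part of what the source reports. "The series", "measured", "known", "first", "only" and "open" are said of these compounds alone.

In a functional assay on THP-1 cells (Homo sapiens) for inhibition (on this read-out lower numbers stand for stronger inhibition of growth and higher numbers for weaker inhibition of growth), compound 1 (`Cc1noc(C)c1-c1ccc2c(c1)c(Cc1ccccc1)cn2CCCCCC(=O)NO`) gives 15500 nM, compound 2 (`Cc1noc(C)c1-c1ccc2c(c1)c(CCc1ccc(F)cc1)cn2CCCCCC(=O)NO`) gives 15500 nM and compound 3 (`Cc1noc(C)c1-c1ccc2c(c1)c(CCc1ccc(F)cc1)cn2CCCCCCC(=O)NO`) gives 15500 nM. Compound 3 therefore stands level with compounds 1 and 2 at the digits reported. Compound 4 (`Cc1ccc(Cc2cn(CCCCCCC(=O)NO)c3ccc(-c4c(C)noc4C)cc23)cc1`) has not been measured. The change from compound 3 is 4-methylphenyl in place of 4-fluorobenzyl on a saturated chain carbon bound to an aromatic carbon. In words, this is 4-methylphenyl in place of 4-fluorobenzyl on a saturated chain carbon bound to an aromatic carbon, which cut one bond further out reads 2-(4-fluorophenyl)ethyl to 4-methylbenzyl.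

Within the data shown here, two measured steps bear on this. At the same place, the series shows no change at the digits printed from compound 1 to compound 2 (within the scatter). On the chain ending in hydroxycarbamoyl, it shows no change at the digits printed from compound 2 to compound 3 (within the scatter). Neither gives any sign of movement, so no step beyond the scatter is expected in this assay, in either direction. The expected step is no change at the digits printed from compound 3 to compound 4 (within the scatter). For compound 4 the estimate is 15500 nM, with an expected range of 7000 nM to 30000 nM.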

Compound 4, concentration for 50% growth inhibition: 15500 nM
The estimate for compound 4 equals the measured number at the digits printed; the measured number falls inside the stated range.
By their numbers in this assay, from the lowest: compounds 1, 2, 3 and 4 (each within the scatter of the next).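

In this assay, the exchange of 4-fluorobenzyl for 4-methylphenyl on a saturated chain carbon bound to an aromatic carbon gives no change at the digits printed from compound 3 to compound 4 (within the scatter). Among these compounds, this step adds something the earlier compounds did not show: the flat read-out at this place also holds on the chain of compound 3, and it holds when the fluorine-bearing group of 8 heavy atoms gives way to the all-carbon group of 7 heavy atoms. Nothing measured here accounts for the flat result.

Still open is whether any group at this place can move the read-out, since the compounds shown carry no amine or carboxylic acid there. Also open, from the compounds shown here alone, is whether a longer chain, or a carboxylic acid in place of hydroxycarbamoyl, would shift the value.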